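Swapping a Chloro for a Methoxyphenoxy Group

This account rests on a few compounds, and the source may have more. Where it says the series, first, only, none or still open, it means among the compounds named here.

Compound 1 `N#Cc1c(Oc2ccc(OC(F)(F)F)cc2)ccnc1N1CCC(NC(=S)Nc2cccnc2)CC1` gives 180 nM in an assay on membranes from brain for binding affinity to Lysophosphatidylserine lipase ABHD12 (Mus musculus), read by fluorescence, with a stated time of 20 min; a lower number here means a stronger inhibitor, a higher number a weaker inhibitor.
Compound 2 `FC(F)(F)Oc1ccc(Oc2ccnc(N3CCC[C@H](NC(=S)Nc4cccnc4)C3)c2Cl)c(Cl)c1` gives only a limit of the assay, > 100000 nM.
Compound 3 `S=C(Nc1cccnc1)NC1CCN(c2cc(Cl)ccn2)CC1` gives 2100 nM in this assay.

Two of the three results are numbers, and compound 3 stands at the higher of them, meaning the weaker inhibitor of the two. Compound 1 sits at a lower number, and the gap between them lies beyond the scatter. Compound 2 sits at the limit of > 100000 nM in this assay, at which 1 of the 3 values shown sits.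

Compound 4 `COc1ccc(Oc2ccnc(N3CCC(NC(=S)Nc4cccnc4)CC3)c2)cc1` differs from compound 3 by 4-methoxyphenoxy in place of chloro on an aromatic carbon. Among the measured compounds shown here, no measured pair shows this exact change, so the expectation rests on the values of compound 1 and compound 3 taken side by side: compound 1 carries an aryloxy group in the shared core and gives 180 nM, whereas compound 3 with its chloro gives 2100 nM. On that basis compound 4 is expected to fall to a lower number than compound 3, a step estimated as a 4.2-fold lower number from compound 3 to compound 4 (0.62 log units; beyond the scatter), beyond the scatter. For compound 4 the estimated value in this assay is 500 nM, with a range from 120 nM to 2500 nM.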

Compound 4, half-maximal inhibitory concentration: 2900 nM
Estimate against measurement, compound 4: 5.8-fold (0.76 log units) below; measured number above the stated range.
By their numbers in this assay, from the lowest: compound 1; then compounds 3 and 4 (each within the scatter of the next). At a limit, above all of these: compound 2.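

Among the compounds shown here, this pair gives the first direct reading at this position, opposite the ring nitrogen: replacing chloro, 1 heavy atom, with 4-methoxyphenoxy, 9 heavy atoms including an aromatic ring, gives a 1.4-fold higher number from compound 3 to compound 4 (0.14 log units; within the scatter) in this assay, so the larger group leaves the value within the usual scatter. An aryloxy group at this position therefore does not, in this pair, give a stronger inhibitor, and compound 1 at 180 nM differs from compound 4 in more than one place, so no step can be read between them. Nothing shown here speaks to the reason for this result.

Still open, going by these compounds, is whether an amine or a carboxylic acid at this position would give a value different from chloro or 4-methoxyphenoxy. Also open, on these data alone, is whether a nitrile alone, added to the shared core of compound 4, would change the value.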